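The source may hold more compounds than are shown below. What is called first, only, known or untested is meant among the compounds shown, and "the series" means these compounds.

Measured in a functional assay on SN12C cells (Homo sapiens) for inhibition, read by sulforhodamine B assay, with a stated time of 48 h; on this read-out lower numbers stand for stronger inhibition of growth and higher numbers for weaker inhibition of growth:

Compound 1 `COc1cc(-c2nn(-c3cccc(NC(=O)Nc4cc(C(F)(F)F)cc(C(F)(F)F)c4)c3)cc2-c2ccncc2)ccc1Cl`: 3320 nM
Compound 2 `COc1cc(-c2nn(-c3cccc(NC(=O)c4cccc(C(F)(F)F)c4)c3)cc2-c2ccncc2)ccc1Cl`: > 50000 nM

Only compound 1 has a true number here. Compound 2 gives > 50000 nM, which is a limit of the assay and not a number. So the data show only that compound 2 reached that limit: the limit of > 50000 nM in this assay, at which 1 of the 2 values shown sits.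

Compound 3 `COc1cc(-c2nn(-c3cccc(NC(=O)Nc4ccc(Cl)c(C(F)(F)F)c4)c3)cc2-c2ccncc2)ccc1Cl` has not yet been measured. It differs from compound 2 as follows: (4-chloro-3-(trifluoromethyl)phenyl)amino in place of 3-(trifluoromethyl)phenyl on a carbonyl carbon. In words, this places (4-chloro-3-(trifluoromethyl)phenyl)amino in place of 3-(trifluoromethyl)phenyl on a carbonyl carbon.

Compound 1 also has a substituted phenylamino group on that carbonyl carbon and gives 3320 nM, so compound 3 is expected to return a number near that value rather than a limit. Among the compounds with values here, with only this one comparison, the expectation remains loose. The expected step, an at least 12-fold lower number from compound 2 to compound 3 (1.09 log units; beyond the scatter), runs toward stronger inhibition of growth and lies beyond the usual scatter. Its true size cannot be fixed from a limit. For compound 3 the estimated value in this assay is 4000 nM, with an expected range of 1400 nM to 20000 nM.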

Compound 3, concentration for total growth inhibition: 9230 nM
The estimate for compound 3 lay 2.3-fold (0.36 log units) below the measured number; low and high end bracket the measured number.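

In this assay, placing (4-chloro-3-(trifluoromethyl)phenyl)amino in place of 3-(trifluoromethyl)phenyl on the carbonyl carbon gives an at least 5.4-fold lower number from compound 2 to compound 3 (0.73 log units; beyond the scatter). As far as these compounds go, the true size of this step stays unknown because compound 2 has no real number, only a limit: the limit of > 50000 nM in this assay, at which 1 of the 3 values shown sits. Compound 3 is now the second compound, after compound 1, with a substituted phenylamino group on that carbonyl carbon to return a true number in this assay, so this result no longer rests on a single case.

The entering group brings a nitrogen with its hydrogen-bond donor and a chlorine on the ring in one change, and the compounds shown cannot separate what each of the two contributes to the step. From the compounds shown here alone, it also remains open how a cyclohexylamino group, which has no aromatic ring, would behave on the same carbonyl carbon, and so whether the aromatic ring is needed for a true number in this assay.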